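Working notes: a new chain on compound 2

The source may report more compounds than this note shows. Statements on the series, on what has been measured and on what is new or still open speak of the compounds shown alone.

- compound 1 `O=C1C=CC(O)(c2cc3ccccc3n2S(=O)(=O)c2ccccc2)C=C1`: 30 nM
- compound 2 `O=C1C=CC(O)(c2cc3ccc(F)cc3n2S(=O)(=O)c2ccccc2)C=C1`: 30 nM
- compound 3 `CCOC(=O)Nc1ccc(S(=O)(=O)n2c(C3(O)C=CC(=O)C=C3)cc3ccccc32)cc1`: 30 nM

In a functional assay on HCT-116 cells (Homo sapiens) for inhibition, read by MTT assay, with a stated time of 72 h (a higher number here means a weaker inhibitor, a lower number a stronger inhibitor), compound 2 gives 30 nM, level with compound 1 and compound 3 at the digits shown. The next compound, not yet measured, is compound 4 `COC(=O)CCc1ccc(S(=O)(=O)n2c(C3(O)C=CC(=O)C=C3)cc3ccc(F)cc32)cc1`. The change is 2-(methoxycarbonyl)ethyl in place of hydrogen on an aromatic carbon, para to a large group.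

Among the compounds with values here, no measured compound carries this chain, so the evidence is indirect. The nearest measured step puts (ethoxycarbonyl)amino in place of hydrogen on an aromatic carbon and shows no change at the digits printed from compound 1 to compound 3 (within the scatter). The fluoro step, already present in compound 2, shows no change at the digits printed from compound 1 to compound 2 (within the scatter). Within the data shown here, neither step moves the value beyond the scatter, though these are only two steps, and neither combines fluoro with a larger group. No step beyond the scatter is therefore expected in this assay, and no direction is favoured. The expected size of the change is a 1.2-fold higher number from compound 2 to compound 4 (0.07 log units; within the scatter). Compound 4 is estimated at 35 nM, with an expected range of 12 nM to 100 nM.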

Compound 4, half-maximal inhibitory concentration: 30 nM
Compound 4: the middle estimate sits 1.2-fold (0.07 log units) above what was measured; the range from low to high includes it.
By their numbers in this assay, from the lowest: compounds 1, 2, 3 and 4 (each within the scatter of the next).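

In this assay, 2-(methoxycarbonyl)ethyl in place of hydrogen on an aromatic carbon, para to a large group, gives no change at the digits printed from compound 2 to compound 4 (within the scatter). Within the data shown here, compound 4 shows what the earlier steps could not: fluoro and a larger group carried together, with the read-out still inside the scatter, so this position takes an added chain of 6 heavy atoms on the fluoro compound without a readable loss or gain. No measurement shown offers a reason for this flat result.

With all four compounds level at the digits printed, no group shown marks where this tolerance ends. Still open, from the compounds shown here alone, is whether a free carboxylic acid in place of the methyl ester, an amine at the end of the chain, or a longer chain would hold the value at this position.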